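The source may hold more compounds than are shown below. What is called first, only, known or untested is meant among the compounds shown, and "the series" means these compounds.

Measured so far, in a functional assay on the whole organism with Mus musculus as the target, in the maximal electroshock model, at a dose of 50 mg/kg by the oral route; a higher number here means more inhibition at the dose given (going by the name of the read-out), a lower number less inhibition:

compound 1, `CN(C)CCCOc1ccccc1/C=C/c1ccccc1`: 14.2%
compound 2, `CN(C)CCCCOc1ccccc1/C=C/c1cccc(Cl)c1`: 14.3%
compound 3, `COc1ccccc1/C=C/c1ccccc1OCCCCN(C)C`: 0%

Compound 1 stands second highest of the three numbers in this assay. Its nearest neighbour is compound 2, which sits within the usual scatter of it; the furthest is compound 3, which lies beyond the scatter below it. Going by the values given here, the one step between compounds differing in a single place is a number 14.3 percentage points lower from compound 2 to compound 3 (beyond the scatter), a change on the aryl group at the far end of the double bond, not on the amine end of the chain.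

The next compound is compound 4, `CCCN(CCC)CCCCOc1ccccc1/C=C/c1ccccc1`. It differs from compound 1 as follows: (dipropylamino)methyl in place of dimethylamino on a saturated chain carbon, three bonds along the chain from an oxygen on an aromatic ring. Among the compounds with values here, no measured step touches the amine or the saturated chain, so the only guide is that compound 1 and compound 2, which share the dimethylamino group on chains of different length, give numbers within the scatter of each other. Within the data shown here, the change to compound 4 therefore has no measured precedent, and no step beyond the scatter is expected in this assay in either direction; the estimated step is a number 0.8 percentage points higher from compound 1 to compound 4 (within the scatter). Compound 4 is expected to give about 15%, in the range 0% to 35%.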

Compound 4, a percentage reported as inhibition, in the whole organism at one dose (the size of the read-out at that dose, not a potency): 0%
Estimate against measurement, compound 4: 15 percentage points above; the measured number falls inside the stated range.
By their numbers in this assay, from the lowest: compounds 3 and 4 (each within the scatter of the next); then compounds 1 and 2 (each within the scatter of the next).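

In this assay, the step at the amine end of the chain, a number 14.2 percentage points lower from compound 1 to compound 4 (beyond the scatter), shows that this place is not indifferent to the group it carries, which the earlier step on the far aryl group could not show. The change puts (dipropylamino)methyl, with 8 heavy atoms, in place of dimethylamino, with 3, on a saturated chain carbon, three bonds along the chain from an oxygen on an aromatic ring, while the counts of hydrogen-bond donors and acceptors and the net charge stay the same, so the heavy-atom count is the only one of these counts that differs. No measurement at hand accounts for this drop.

As far as these compounds go, the change brings the two propyl groups and the extra methyl-derived chain carbon together, so it remains open which of them goes with the lower number, and dipropylamino directly in place of dimethylamino would separate them. Also open, from the compounds shown here alone, is how a diethylamino, pyrrolidine or morpholine group at this place would read in this assay.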